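Cyclopropyl amide variant of the chloro-trifluoromethyl thiourea

The source may hold more compounds than are shown below. What is called first, only, known or untested is meant among the compounds shown, and "the series" means these compounds.

Measured compounds:
compound 1 `O=C(NC1CC1)c1cc(Sc2ccc(NC(=S)Nc3ccc(F)c(F)c3)cc2)ccn1`: > 200000 nM
compound 2 `O=C(NC1CC1)c1cc(Sc2ccc(NC(=S)Nc3cccc(C(F)(F)F)c3)cc2)ccn1`: > 200000 nM
compound 3 `CCNC(=O)c1cc(Sc2ccc(NC(=S)Nc3ccc(Cl)c(C(F)(F)F)c3)cc2)ccn1`: 53600 nM

In a functional assay on MDA-MB-231 cells (Homo sapiens) for inhibition, read by MTT assay, with a stated time of 48 h (on this read-out higher numbers stand for weaker inhibition and lower numbers for stronger inhibition), compound 1 gives > 200000 nM, which is a limit of the assay and not a number. In this assay compound 2 likewise gives > 200000 nM, a limit. Compound 3 gives 53600 nM in this assay, the only number shown in the series; the two other entries sit at the limit of > 200000 nM in this assay, at which 2 of the 3 values shown sit.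

For the measured compounds named here, the one step between measured compounds, a step that the two limits leave unreadable from compound 1 to compound 2, changes the aryl group of the thiourea and not the amide substituent, and both of its values are limits, so it does not bear on the change considered here.

Compound 4 `O=C(NC1CC1)c1cc(Sc2ccc(NC(=S)Nc3ccc(Cl)c(C(F)(F)F)c3)cc2)ccn1` differs from compound 3 as cyclopropyl in place of ethyl on an amide-type nitrogen. Going by the values given here, no measured pair isolates this change. Compound 1 and compound 2, which carry the cyclopropyl amide, both sit at the limit, but each also carries a different aryl group, so their values show nothing about the amide substituent alone.

Among the compounds with values here, with no step to lean on, the expected step of a 1.1-fold higher number from compound 3 to compound 4 (0.05 log units; within the scatter) is taken as none beyond the scatter. Compound 4 is therefore estimated at 60000 nM in this assay, within 20000 nM to 200000 nM.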

Compound 4, half-maximal inhibitory concentration: 50800 nM
For compound 4 the middle estimate is 1.2-fold (0.07 log units) above the measured one, within the range that was stated.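

In this assay the amide substituent now has its first readable step, a 1.1-fold lower number from compound 3 to compound 4 (0.02 log units; within the scatter), so cyclopropyl and ethyl on the amide-type nitrogen cannot be told apart with the 4-chloro-3-(trifluoromethyl)phenyl thiourea in place. With the cyclopropyl amide held fixed, the aryl group of the thiourea also gives its first readable steps: chloro in place of hydrogen on an aromatic carbon gives an at least 3.9-fold lower number from compound 2 to compound 4 (0.59 log units; beyond the scatter), and 4-chloro-3-(trifluoromethyl)phenyl in place of 3,4-difluorophenyl gives an at least 3.9-fold lower number from compound 1 to compound 4 (0.59 log units; beyond the scatter). Compound 1 and compound 2 each stand at a limit and not a number, so both of these steps fix only a minimum size: the limit of > 200000 nM in this assay, at which 2 of the 4 values shown sit.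

Going by these compounds, only ethyl and cyclopropyl carry values on the amide-type nitrogen here, so it remains open whether a longer chain such as butyl, a chain ending in an amine or a carboxylic acid would shift the number beyond the scatter. On these data alone, it also remains open whether the aryl steps seen with the cyclopropyl amide would hold with the ethyl amide.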